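Toxicity limit and the step to compound 4

This account rests on a few compounds, and the source may have more. Where it says the series, first, only, none or still open, it means among the compounds named here.

In an ADME assay on BHK-21 cells (Mesocricetus auratus) for cytotoxicity, read by MTT assay, with a stated time of 72 h (on this read-out lower numbers stand for higher toxicity in this test and higher numbers for lower toxicity in this test), compound 3 (`Cc1ccc(-c2nn(-c3ccccc3)cc2CNc2ccc(Br)cc2)cc1`) gives > 100000 nM as a limit of the assay. Compound 1 (`Brc1ccc(NCc2cn(-c3ccccc3)nc2-c2ccccc2)cc1`) gives > 100000 nM as a limit too. Compound 3 therefore stands at the limit of > 100000 nM in this assay, at which 2 of the 3 values shown sit, and has no exact number. Among the compounds with values here, compound 2 (`FC(F)(F)c1ccc(NCc2cn(-c3ccccc3)nc2-c2ccc(Br)cc2)cc1`) gives the only exact number, 20000 nM in this assay and it also holds the 4-bromophenyl group, though it differs from compound 4 elsewhere.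

Compound 4 (`Brc1ccc(NCc2cn(-c3ccccc3)nc2-c2ccc(Br)cc2)cc1`) arises through bromo in place of methyl on an aromatic carbon and so has bromo in place of methyl on an aromatic carbon. Within the data shown here, the one measured step bearing on this is a step that the two limits leave unreadable from compound 1 to compound 3 and it offers no size to carry over. Among the measured compounds shown here, with compound 2 at 20000 nM as the sole guide, a modest shift toward higher toxicity in this test is expected. A reading at the limit remains possible for compound 4. The expected change is an at least 2.0-fold lower number from compound 3 to compound 4 (0.30 log units; that floor lies within the scatter) as a rough estimate only. Compound 4 is estimated at 50000 nM with an expected range from 15000 nM to 100000 nM in this test.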

Compound 4, half-maximal cytotoxic concentration: > 100000 nM
Compound 4: no number, only a limit (the forecaster's own chance of this, stated with the estimate: 40%); middle value at least 2.0-fold (0.30 log units) from the limit.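

Bromo in place of trifluoromethyl gives an at least 5.0-fold higher number from compound 2 to compound 4 (0.69 log units; beyond the scatter), so in this assay the 4-bromophenyl group alone does not bring the reading of compound 2 with it: compound 4 carries that group too and reads at the limit. The steps that change the 4-phenyl substituent, whether from hydrogen or from methyl to bromo, cannot be read, as both ends of each are limits. The series therefore gains one readable step, and only on the trifluoromethyl side: the limit of > 100000 nM in this assay, at which 3 of the 4 values shown sit.

Going by these compounds, only compound 2 holds a trifluoromethyl group, so whether it gives an exact reading on the cores of compound 1 and compound 3 stays open. On these data alone, how an amine or a carboxylic acid in place of the bromo would read in this assay also stays open.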